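Aryl in Place of tert-Butyl: Expected Antiproliferative Shift

This account rests on a few compounds, and the source may have more. Where it says the series, first, only, none or still open, it means among the compounds named here.

Compound 1, `CC(C)(C)OC(=O)N1CCN(C(=S)SCc2cn(C[C@H](O)[C@H]3OC(=O)C(OCc4ccccc4)=C3OCc3ccccc3)nn2)CC1`: > 100000 nM
Compound 2, `CC(C)(C)c1cn(C[C@H](O)[C@H]2OC(=O)C(OCc3ccccc3)=C2OCc2ccccc2)nn1`: 29200 nM

Both readings come from a functional assay on HepG2 cells (Homo sapiens) for antiproliferative activity, read by MTT assay, with a stated time of 72 h; on this read-out lower numbers stand for stronger inhibition and higher numbers for weaker inhibition. Compound 1 reaches only (the limit of > 100000 nM in this assay, at which 1 of the 2 values shown sits), which is a limit of the assay and not a number. Among the compounds with values here, compound 2 gives 29200 nM, the only true number among the two, so it has no measured neighbour against which a step could be weighed. Compound 3, `COc1ccc(-c2cn(C[C@H](O)[C@H]3OC(=O)C(OCc4ccccc4)=C3OCc3ccccc3)nn2)cc1`, differs from compound 2 in one place: 4-methoxyphenyl in place of tert-butyl on an aromatic carbon, in words, 4-methoxyphenyl in place of tert-butyl on an aromatic carbon. Since no measured step of this kind exists among these compounds, the expectation rests on the change alone; a moderate move toward stronger inhibition in this assay seems the more likely direction, though a result within the usual scatter cannot be ruled out. Compound 3 is therefore expected at 10000 nM, between 3000 nM and 40000 nM, an estimated step of a 2.9-fold lower number from compound 2 to compound 3 (0.47 log units; beyond the scatter).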

Compound 3, half-maximal inhibitory concentration: 46400 nM
The estimate for compound 3 lay 4.6-fold (0.67 log units) below the measured number; the whole stated range lies below it.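

Placing 4-methoxyphenyl in place of tert-butyl on an aromatic carbon of the five-membered aromatic ring with 3 nitrogen gives, in this assay, a 1.6-fold higher number from compound 2 to compound 3 (0.20 log units; within the scatter) and so the two compounds cannot be told apart. This position therefore accepts a group of 8 heavy atoms with a six-membered aromatic ring in place of one of 4 heavy atoms with no ring, and the reading does not move beyond the usual scatter. Nothing among the measurements offers a reason for this outcome.

A plain phenyl group at this position would show what the methoxy part of 4-methoxyphenyl adds to the ring alone. From the compounds shown here alone, whether an amine or a carboxylic acid on the same carbon would shift the reading in either direction remains open.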